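Moving the pyridine nitrogen in compound 4

The source may hold more compounds than are shown below. What is called first, only, known or untested is meant among the compounds shown, and "the series" means these compounds.

Compound 1 `C/C(=C\C(=O)Nc1ccccc1OCCCC(=O)O)c1ccc2c(ccn2C(CC(C)C)c2ccccc2)c1`: 6.3 nM
Compound 2 `C/C(=C\C(=O)Nc1ccccc1OCCCC(=O)O)c1ccc2c(ccn2C(c2ccccc2)c2ccc(C(F)(F)F)cc2)c1`: 8.1 nM
Compound 3 `C/C(=C\C(=O)Nc1ccccc1OCCCC(=O)O)c1ccc2c(ccn2C(c2ccccc2)c2ccccn2)c1`: 37 nM

These three compounds share one core and differ only in the group on a saturated chain carbon bound to an aromatic carbon and an aromatic nitrogen. In an assay on Prostate gland for inhibition of steroid 5-alpha-reductase (Rattus norvegicus) (on this read-out higher numbers stand for weaker inhibition and lower numbers for stronger inhibition), compound 3 gives the highest of the three numbers; the steps that lead to it are a 5.9-fold higher number from compound 1 to compound 3 (0.77 log units; beyond the scatter) and a 4.6-fold higher number from compound 2 to compound 3 (0.66 log units; beyond the scatter). Compound 4 `C/C(=C\C(=O)Nc1ccccc1OCCCC(=O)O)c1ccc2c(ccn2C(c2ccccc2)c2cccnc2)c1` carries the change (pyridin-3-yl in place of pyridin-2-yl on a saturated chain carbon bound to an aromatic carbon and an aromatic nitrogen). For the measured compounds named here, no measured step swaps one pyridinyl for another, so the two steps bear only indirectly: both show pyridin-2-yl giving a higher number than a carbon-only group, and pyridin-3-yl keeps the nitrogen. The expected step is therefore modest, a 1.9-fold lower number from compound 3 to compound 4 (0.27 log units; within the scatter), close to the scatter. Compound 4 is estimated at 20 nM, in the range 6 nM to 60 nM.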

Compound 4, half-maximal inhibitory concentration: 47 nM
The estimate for compound 4 lay 2.4-fold (0.37 log units) below the measured number, within the range that was stated.
By their numbers in this assay, from the lowest: compounds 1 and 2 (each within the scatter of the next); then compounds 3 and 4 (each within the scatter of the next).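

In this assay, the pyridine nitrogen can occupy either ring position without a change that stands out from the scatter (a 1.3-fold higher number from compound 3 to compound 4 (0.10 log units; within the scatter)). Pyridin-3-yl also stays clearly apart from the groups without a ring nitrogen (a 5.8-fold higher number from compound 2 to compound 4 (0.76 log units; beyond the scatter) and a 7.5-fold higher number from compound 1 to compound 4 (0.87 log units; beyond the scatter)), so both pyridines shown fall on the same side of that gap. No available evidence explains this gap. Pyridin-4-yl remains open, as it could fall with the other two pyridines or nearer compound 2. Also open, on these data alone, is how a pyridine carrying a trifluoromethyl group would compare.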